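The compounds below may be only part of what the source reports. "The series", "measured", "known", "first", "only" and "open" are said of these compounds alone.

Of the compounds shown here, three built on a shared core have been measured in an assay on cells for displacement of a labelled ligand from adenosine receptor A1 (Homo sapiens), read by scintillation counting and radioligand binding, with a stated time of 60 min; a higher number here means a weaker inhibitor, a lower number a stronger inhibitor. Compound 1 `CN1CCN(c2nc(-c3ccc(Cl)c(Cl)c3)nc3[nH]cnc23)CC1` gives 631 nM. Compound 2 `CN1CCN(c2nc(-c3cccc(Cl)c3)nc3[nH]cnc23)CC1`, which carries a hydrogen in place of one chloro on an aromatic carbon, gives 79.4 nM. That single change produced a 7.9-fold lower number from compound 1 to compound 2 (0.90 log units; beyond the scatter). Compound 3 `Oc1cccc(-c2nc(N3CCCCC3)c3nc[nH]c3n2)c1` gives 10 nM, the lowest of the three numbers; compound 2 stands nearest to it and compound 1 furthest, both gaps beyond the scatter.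

Compound 4 `CN1CCN(c2nc(-c3cccc(O)c3)nc3[nH]cnc23)CC1` has not yet been measured. It differs from compound 3 in one place: 4-methylpiperazin-1-yl in place of piperidin-1-yl on an aromatic carbon. Going by the values given here, no measured step bears on this change. Among the compounds with values here, the only step with one difference alters a chloro on an aromatic carbon elsewhere in the molecule, not the ring that is swapped here. Compound 2 does carry the same 4-methylpiperazin-1-yl as compound 4, but it also differs from compound 3 in its aryl group, so its number cannot be set against compound 3 directly. Without a direct guide, the expectation for compound 4 is a step of a 3.0-fold higher number from compound 3 to compound 4 (0.48 log units; beyond the scatter), leaning slightly toward a higher number with wide uncertainty. Compound 4 is therefore estimated at 30 nM, with a range from 5 nM to 200 nM.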

Compound 4, inhibition constant: 158 nM
Compound 4: middle estimate off by 5.3-fold (0.72 log units), on the low side; the measured number falls inside the stated range.
By their numbers in this assay, from the lowest: compound 3; then compounds 2 and 4 (each within the scatter of the next); then compound 1.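

In this assay, going by these compounds alone, swapping piperidin-1-yl for 4-methylpiperazin-1-yl on this aromatic carbon gives a 16-fold higher number from compound 3 to compound 4 (1.20 log units; beyond the scatter) and is the first measured step to show that the group at this position can change the number well beyond the scatter. With 4-methylpiperazin-1-yl held fixed, the aryl group can be read too: hydroxy in place of chloro gives a 2.0-fold higher number from compound 2 to compound 4 (0.30 log units; within the scatter) so compound 2 and compound 4 cannot be told apart. Replacing 3,4-dichlorophenyl with 3-hydroxyphenyl gives a 4.0-fold lower number from compound 1 to compound 4 (0.60 log units; beyond the scatter) and so stays beyond the scatter, as the removal of one chloro did earlier.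

The data shown offer no measurement that explains any of these steps. From the compounds shown here alone, whether an unsubstituted piperazine, a morpholine or an open-chain dimethylamino group on this carbon would land nearer compound 3 or compound 4 remains open, as does whether the same ring swap would give a step of similar size with a chloro-bearing aryl group in place of 3-hydroxyphenyl.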